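Chloro in Place of Hydroxy on a Flavone Core

A few compounds are considered here, and "the series" means these few. Any claim that something is new, unique, unknown or untested is made for them only; others in the source may bear on it.

The account follows a single change on the core of compound 1 `COc1cc(OC)c(-c2cc(=O)c3cc(O)ccc3o2)cc1OC`. In a functional assay on HeLa cells (Homo sapiens) for inhibition, read by MTT assay, with a stated time of 72 h (a lower number here means a stronger inhibitor, a higher number a weaker inhibitor), compound 1 returns only a limit, > 150000 nM. Two chalcones accompany it. Compound 2 `COc1cc(OC)c(OC)cc1/C=C/C(=O)c1ccc(O)cc1O` gives 37600 nM in this assay. Compound 3 `COc1cc(C(=O)/C=C/c2cc(OC)c(OC)cc2OC)ccc1O` also reaches only a limit, > 150000 nM. Thus compound 1 stands at the limit of > 150000 nM in this assay, at which 2 of the 3 values shown sit, so its true position is not a number. The new compound 4 `COc1cc(OC)c(-c2cc(=O)c3cc(Cl)ccc3o2)cc1OC` differs from compound 1 in one place: chloro in place of hydroxy on an aromatic carbon. Among the compounds with values here, no measured pair shows this change, so no step size is known; the author expects no shift beyond the scatter, with a fair chance that another limit is reported. Compound 4 is therefore expected near 120000 nM, between 30000 nM and 300000 nM, a step of an at least 1.2-fold lower number from compound 1 to compound 4 (0.09 log units; that floor lies within the scatter) that is estimated, not measured.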

Compound 4, half-maximal inhibitory concentration: > 150000 nM
Compound 4: a limit, no number (the forecaster's own chance of this, stated with the estimate: 55%); middle value at least 1.2-fold (0.09 log units) from the limit.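

Compound 1 and compound 4 both return only a limit in this assay, so no step between them can be read: the limit of > 150000 nM in this assay, at which 3 of the 4 values shown sit.

The compounds shown leave open how chloro in place of hydroxy shifts inhibition on the shared core.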